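This account rests on a few compounds, and the source may have more. Where it says the series, first, only, none or still open, it means among the compounds named here.

In a functional assay on MCF7 cells (Homo sapiens) for inhibition, read by MTT assay, with a stated time of 72 h (on this read-out higher numbers stand for weaker inhibition and lower numbers for stronger inhibition), compound 1 (`Cc1cc(Nc2cc(-c3ccccc3)[nH]n2)n2nc(SCCc3ccccc3)nc2n1`) gives 2700 nM. Compound 2 (`Cc1cc(Nc2cc(-c3ccccc3)[nH]n2)n2nc(SCC3CCCCC3)nc2n1`) gives no number, only a limit of > 50000 nM. That is the limit of > 50000 nM in this assay, at which 1 of the 2 values shown sits.

Compound 3 (`Cc1cc(Nc2cc(-c3ccccc3)[nH]n2)n2nc(SCC(=O)c3ccccc3)nc2n1`) differs from compound 2 by benzoyl in place of cyclohexyl on a saturated chain carbon bound to a sulfur.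

Going by the values given here, one measured step bears on this change. It is an at least 18-fold higher number from compound 1 to compound 2 (1.26 log units; beyond the scatter), which came with cyclohexyl in place of benzyl at that same place. Compound 3 again carries a six-membered aromatic ring, as compound 1 does, so a large step towards a lower number is expected in this assay, resting on that single step. The expected change is an at least 5.5-fold lower number from compound 2 to compound 3 (0.74 log units; beyond the scatter). For compound 3 the estimated value is 9000 nM, with an expected range from 2000 nM to 40000 nM.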

Compound 3, half-maximal inhibitory concentration: 5240 nM
Compound 3: the middle estimate sits 1.7-fold (0.23 log units) above what was measured, and the stated range covers the measured number.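

In this assay, benzoyl gives an at least 9.5-fold lower number from compound 2 to compound 3 (0.97 log units; beyond the scatter), so a second group with a six-membered aromatic ring on the saturated chain carbon bound to a sulfur stands clear of cyclohexyl. Benzoyl and benzyl are not told apart at this place, with a 1.9-fold higher number from compound 1 to compound 3 (0.29 log units; within the scatter), so the carbonyl, with its one hydrogen-bond acceptor, shows no effect beyond the scatter. Compound 2 gives only a limit, so the step from it has no upper end: the limit of > 50000 nM in this assay, at which 1 of the 3 values shown sits.

The compounds shown leave open whether the aromatic ring tolerates a substituent such as chlorine or methoxy, or can be replaced by a pyridine ring. They also leave open how a carboxylic acid or an amine would fare in its place.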